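The compounds below may be only part of what the source reports. "The series", "measured", "known", "first", "only" and "open" are said of these compounds alone.

Of the compounds shown here, three have been measured in a functional assay on cells for antagonist activity at D(4) dopamine receptor (Homo sapiens), read by TR-FRET and cAMP accumulation, with a stated time of 30 min; a lower number here means a stronger inhibitor, a higher number a weaker inhibitor. Compound 2 `Cc1cccc(NC(=O)CCN2CCN(c3ccccn3)CC2)c1` gives 1630 nM in this assay. Compound 1 `CCc1cccc(NC(=O)CN2CCN(c3ccccn3)CC2)c1` gives 1310 nM in this assay; the two numbers lie within the scatter of each other, so no order can be read between them. Compound 3 `O=C(CN1CCN(c2ccc(Cl)cn2)CC1)Nc1cccnc1` gives 40000 nM in this assay, a far higher number. Of the three numbers, compound 2 therefore stands second highest, close to compound 1 and far from compound 3.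

Compound 4 `Cc1cccc(NC(=O)CCN2CCN(c3ncccn3)CC2)c1` has not yet been measured. It differs from compound 2 in one place: pyrimidin-2-yl in place of pyridin-2-yl on an amine nitrogen in a ring. The amide linker and the aromatic ring carrying the methyl group stay as they are. Going by the values given here, no measured pair in this set shows the same change, so its effect cannot be read from these data. The change keeps the count of heavy atoms and adds one acceptor, which suggests a step of modest size, leaning toward a higher number. Compound 4 is expected to give about 2500 nM in this assay, within a range from 800 nM to 8000 nM. That estimate means a 1.5-fold higher number from compound 2 to compound 4 (0.19 log units; within the scatter), a step that may well fall within the scatter.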

Compound 4, half-maximal inhibitory concentration: 2120 nM
Estimate against measurement, compound 4: 1.2-fold (0.07 log units) above, within the range that was stated.
By their numbers in this assay, from the lowest: compounds 1, 2 and 4 (each within the scatter of the next); then compound 3.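

In this assay the exchange of pyridin-2-yl for pyrimidin-2-yl on an amine nitrogen in a ring gives a 1.3-fold higher number from compound 2 to compound 4 (0.11 log units; within the scatter) and so provides the only direct reading of this position among the compounds shown. Compounds 2 and 4 cannot be told apart by this measurement. The entering ring has two hetero atoms and two hydrogen-bond acceptors where the leaving ring has one of each, yet in this single pair that difference leaves no readable mark on the number. Nothing available explains this outcome, so the pair records an observation and not a reason.

A single pair cannot show whether the same exchange would behave this way with another amide linker or another aromatic ring on the amide nitrogen. It also leaves open what would happen at this position with a plain phenyl ring, which has no ring nitrogen, or with a pyridin-2-yl ring carrying a methoxy group or a chlorine atom.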